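The source may hold more compounds than are shown below. What is called first, only, known or untested is meant among the compounds shown, and "the series" means these compounds.

Measured compounds:
- compound 1, `COc1ncc(-c2ccc3c(c2)N(c2ccc(C)cc2)C(=O)CO3)cc1NS(=O)(=O)c1ccc(F)cc1`: 28300 nM
- compound 2, `Cc1ccc(N2C(=O)COc3ccc(-c4cnc(Cl)c(NS(=O)(=O)c5ccc(F)cc5)c4)cc32)cc1`: 39600 nM
- compound 3, `O=C1COc2ccc(-c3cnc4ccccc4c3)cc2N1`: 26300 nM

All three numbers come from a functional assay on HepG2 cells (Homo sapiens) for antiproliferative activity, read by MTT assay, with a stated time of 72 h; a lower number here means a stronger inhibitor, a higher number a weaker inhibitor. Compound 1 stands second highest of the three, but every gap to it lies within the scatter: compound 3 sits close by, and the step of a 1.4-fold higher number from compound 1 to compound 2 (0.15 log units; within the scatter) is also within the scatter. Compound 4, `COc1ncc(-c2ccc3c(c2)N(C(C)C)C(=O)CO3)cc1NS(=O)(=O)c1ccc(F)cc1`, differs from compound 1 in one place: isopropyl in place of 4-methylphenyl on an amide-type nitrogen in a ring. No measured step touches this amide nitrogen, so nothing shown bears directly on it; the only guidance is that all three compounds, with different groups around the core, give similar weak numbers. The step from compound 1 to compound 4 is therefore expected to be small, a 1.1-fold higher number from compound 1 to compound 4 (0.05 log units; within the scatter), with no direction beyond the scatter. Compound 4 is estimated at 32000 nM, between 10000 nM and 90000 nM.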

Compound 4, half-maximal inhibitory concentration: 37200 nM
Beside the measured number, compound 4's estimate is 1.2-fold (0.07 log units) below it; measured number inside the range.
By their numbers in this assay, from the lowest: compounds 3, 1, 4 and 2 (each within the scatter of the next).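

Among these compounds, this is the first measured step at the amide-type nitrogen in a ring. In this assay putting isopropyl in place of 4-methylphenyl removes the six-membered aromatic ring and takes the group from 7 heavy atoms to 3, yet it gives a 1.3-fold higher number from compound 1 to compound 4 (0.12 log units; within the scatter) so this large change of group leaves the number unchanged within the scatter. Nothing measured here offers an explanation for this result.

As far as these compounds go, whether a chain ending in an amine or a carboxylic acid on this nitrogen would move the number beyond the scatter stays open.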